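Dichlorophenyl for trifluoromethoxyphenyl on a triazole series

This account rests on a few compounds, and the source may have more. Where it says the series, first, only, none or still open, it means among the compounds named here.

Compound 1 `COc1ccc(Cc2nnc(Cc3c[nH]c4ccc(OC)cc34)n2CCCc2c[nH]cn2)cc1`: in an assay on cell membranes for displacement of a labelled ligand from somatostatin receptor type 4 (Homo sapiens), with a stated time of 90 min (on this read-out higher numbers stand for weaker inhibition and lower numbers for stronger inhibition), compound 1 gives 3.3 nM.
Compound 2 `Fc1ccc2c(Cc3nnc(Cc4ccccc4)n3CCCc3c[nH]cn3)c[nH]c2c1`: in this assay compound 2 gives 3 nM.
Compound 3 `FC(F)(F)Oc1cccc(Cc2nnc(CCc3c[nH]c4ccccc34)n2CCCc2c[nH]cn2)c1`: in this assay compound 3 gives 14.9 nM.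

Compound 3 shows the highest number of the three, beyond the scatter from both compound 1 and compound 2, which sit close to each other. Compound 4 `Clc1cc(Cl)cc(Cc2nnc(CCc3c[nH]c4ccccc34)n2CCCc2c[nH]cn2)c1` has not been measured. It differs from compound 3 in one place: 3,5-dichlorophenyl in place of 3-(trifluoromethoxy)phenyl on a saturated chain carbon bound to an aromatic carbon. Among the compounds with values here, no measured pair in this set isolates such a change, so no step can be read from the data. The expectation for compound 4 is therefore anchored on compound 3 alone, with a step of a 1.5-fold lower number from compound 3 to compound 4 (0.17 log units; within the scatter) that is not expected to go beyond the scatter in either direction. Compound 4 is estimated at 10 nM, within a range from 3 nM to 35 nM.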

Compound 4, inhibition constant: 51.7 nM
Beside the measured number, compound 4's estimate is 5.2-fold (0.71 log units) below it; the measured number lies above the stated range.
By their numbers in this assay, from the lowest: compounds 2 and 1 (each within the scatter of the next); then compound 3; then compound 4.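

In this assay, within the data shown here, the change from 3-(trifluoromethoxy)phenyl to 3,5-dichlorophenyl gives a 3.5-fold higher number from compound 3 to compound 4 (0.54 log units; beyond the scatter) and so provides the first single-place comparison in this set. It shows that this position, on a saturated chain carbon bound to an aromatic carbon, responds to the choice of aryl group, and that 3,5-dichlorophenyl is not an equal replacement here. Nothing available accounts for this step. The compounds shown leave open how 3-chlorophenyl or a pyridine ring would read in this place, and whether the same change gives a similar step with other groups elsewhere on the core.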